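The compounds below may be only part of what the source reports. "The series", "measured", "known", "first", "only" and "open" are said of these compounds alone.

Compound 1 `CCCC(=O)OCSc1ccc(OC)cc1C(=O)NCCC(N)=O`: > 100 uM (a limit)
Compound 2 `CCCC(=O)OCSc1ccccc1C(=O)NC1(C(N)=O)CCCC1`: > 100 uM (a limit)

In an ADME assay on CEM-SS cells (Homo sapiens) for cytotoxicity, read by XTT assay, with a stated time of 6 days (a higher number here means that more compound is tolerated, a lower number that less compound is tolerated), compound 2 gives > 100 uM, which is a limit and not a number. For the measured compounds named here, the series so far shows only (the limit of > 100 uM in this assay, at which 2 of the 2 values shown sit). Compound 3 `CCCC(=O)OCSc1ccccc1C(=O)N[C@@H]1CCC[C@H]1C(N)=O` differs from compound 2 as follows: 2-carbamoylcyclopentyl in place of 1-carbamoylcyclopentyl on an amide-type nitrogen. In words, 2-carbamoylcyclopentyl stands in place of 1-carbamoylcyclopentyl on an amide-type nitrogen. Going by the values given here, no measured step exists between compounds, and no shift beyond the scatter is expected in this assay. The expected change is a number no higher from compound 2 to compound 3 (the limit leaves the size open). For compound 3 the estimate is 100 uM, with an expected range of 40 uM to 200 uM.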

Compound 3, half-maximal toxic concentration: 43.7 uM
The estimate for compound 3 lay 2.3-fold (0.36 log units) above the measured number; the range from low to high includes it.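

In this assay, 2-carbamoylcyclopentyl on the amide-type nitrogen gives an at least 2.2-fold lower number from compound 2 to compound 3 (0.35 log units; beyond the scatter), so this place is sensitive to where the carbamoyl group sits on the five-membered ring. The same atoms joined differently suffice for a step beyond the scatter, and compound 3 gives the first number rather than a limit. The earlier compounds could not show this: the limit of > 100 uM in this assay, at which 2 of the 3 values shown sit.

Still open, from the compounds shown here alone, is whether the shifted carbamoyl group or the two defined stereocentres of compound 3 carry the step. Also open, going by these compounds, is how a carboxylic acid or an amine in place of the carbamoyl group reads in this assay.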